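This account rests on a few compounds, and the source may have more. Where it says the series, first, only, none or still open, it means among the compounds named here.

In an ADME assay on HEK-293T cells (Homo sapiens) for cytotoxicity, read by MTT assay, with a stated time of 24 h (on this read-out lower numbers stand for higher toxicity in this test and higher numbers for lower toxicity in this test), compound 1 (`Cc1ccc(-c2nn(-c3ccccc3)cc2-c2nc3ccccc3n2S(=O)(=O)c2ccccc2)cc1`) gives 138000 nM, compound 2 (`Cc1ccc(-c2nn(-c3ccccc3)cc2-c2nc3ccccc3n2S(=O)(=O)c2cc(C)ccc2C)cc1`) gives 82200 nM and compound 3 (`Cc1ccc(C)c(S(=O)(=O)n2c(-c3cn(-c4ccccc4)nc3-c3ccc(F)cc3)nc3ccccc32)c1`) gives 54200 nM. Compound 3 thus lies within the scatter of compound 2, and its number is clearly lower than that of compound 1. Compound 4 (`O=S(=O)(c1ccc(Br)cc1)n1c(-c2cn(-c3ccccc3)nc2-c2ccc(F)cc2)nc2ccccc21`) carries 4-bromophenyl in place of 2,5-dimethylphenyl on a sulfonyl sulfur. Among the measured compounds shown here, only one measured change touches that place, phenyl to 2,5-dimethylphenyl, a 1.7-fold lower number from compound 1 to compound 2 (0.23 log units; within the scatter). The fluoro for methyl change, a 1.5-fold lower number from compound 2 to compound 3 (0.18 log units; within the scatter), lies at another place and is also small. For the measured compounds named here, no compound with bromine has been measured, so nothing points to a larger change here. The expected 1.0-fold higher number from compound 3 to compound 4 (0.01 log units; within the scatter) stays within the scatter, with no clear direction. Compound 4 is estimated at 55000 nM, with an expected range from 27000 nM to 110000 nM.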

Compound 4, half-maximal cytotoxic concentration: 239000 nM
For compound 4 the middle estimate is 4.3-fold (0.64 log units) below the measured one, outside the stated range (above it).
By their numbers in this assay, from the lowest: compounds 3, 2, 1 and 4 (each within the scatter of the next, the first and the last beyond it).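

In this series the group on the sulfonyl sulfur can shift the number in this assay clearly: 4-bromophenyl in place of 2,5-dimethylphenyl gives a 4.4-fold higher number from compound 3 to compound 4 (0.64 log units; beyond the scatter). Among the compounds shown here, the earlier change at this place, a 1.7-fold lower number from compound 1 to compound 2 (0.23 log units; within the scatter), had stayed within the scatter, so this is the first step here to go beyond it. Nothing available explains the step. The compounds shown leave open whether the bromine or the loss of the two methyl groups carries it. They also leave open how a chlorine or a methoxy group would behave on that phenyl ring.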